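Aryl replacement at the fused bicyclic core: compound 4 expected

A few compounds are considered here, and "the series" means these few. Any claim that something is new, unique, unknown or untested is made for them only; others in the source may bear on it.

Measured in a functional assay on SGC-7901 cells (Homo sapiens) for antiproliferative activity, read by MTT assay, with a stated time of 72 h; a higher number here means a weaker inhibitor, a lower number a stronger inhibitor:
Compound 1 `COc1cc(-n2cnc3ccc(-c4cc(F)ccc4F)cc32)cc(OC)c1OC` gives 6590 nM.
Compound 2 `COc1cc(-n2cnc3ccc(-c4ccccc4)cc32)cc(OC)c1OC` gives 290 nM.
Compound 3 `COc1cc(-n2cnc3ccc(-c4cccc([N+](=O)[O-])c4)cc32)cc(OC)c1OC` gives 380 nM.

Compound 3 holds the second highest of the three numbers; it sits within the scatter of compound 2, as a 1.3-fold higher number from compound 2 to compound 3 (0.12 log units; within the scatter) shows, and far from compound 1. Compound 4 `COc1cc(-n2cnc3ccc(-c4ccc(C)cc4F)cc32)cc(OC)c1OC` differs from compound 3 in one place: 2-fluoro-4-methylphenyl in place of 3-nitrophenyl on an aromatic carbon. Among the compounds with values here, the steps that bear on this are a 23-fold lower number from compound 1 to compound 2 (1.36 log units; beyond the scatter) and a 17-fold lower number from compound 1 to compound 3 (1.24 log units; beyond the scatter), both large, and both moving away from the one compound carrying fluorine on this ring. Compound 4 again carries a fluorine there, so a step back toward compound 1 is expected, though the added methyl leaves the size uncertain; the expected step is a 5.3-fold higher number from compound 3 to compound 4 (0.72 log units; beyond the scatter). Compound 4 is therefore estimated at 2000 nM, within 600 nM to 7000 nM.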

Compound 4, half-maximal inhibitory concentration: 5650 nM
Estimate against measurement, compound 4: 2.8-fold (0.45 log units) below; low and high end bracket the measured number.
By their numbers in this assay, from the lowest: compounds 2 and 3 (each within the scatter of the next); then compounds 4 and 1 (each within the scatter of the next).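

In this assay, 2-fluoro-4-methylphenyl at this position gives a much higher number than 3-nitrophenyl (a 15-fold higher number from compound 3 to compound 4 (1.17 log units; beyond the scatter)) or phenyl (a 19-fold higher number from compound 2 to compound 4 (1.29 log units; beyond the scatter)), but does not separate from 2,5-difluorophenyl (a 1.2-fold lower number from compound 1 to compound 4 (0.07 log units; within the scatter)). Both fluorine-bearing aryl groups shown therefore stand well above the two without fluorine, and the added methyl brings no recovery. Nothing available here accounts for this separation.

As far as these compounds go, the fluorine and methyl of compound 4 enter together, so their separate contributions remain open. From the compounds shown here alone, how an amine or a carboxylic acid on this aryl ring would behave also remains open.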